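This account rests on a few compounds, and the source may have more. Where it says the series, first, only, none or still open, it means among the compounds named here.

Measured series:
Compound 1 `O=C(/C(=C\c1c(O)cc(O)cc1O)S(=O)(=O)c1ccccc1Br)c1ccc(Br)cc1` gives 50000 nM in a functional assay on DU-145 cells (Homo sapiens) for inhibition, read by trypan blue exclusion, with a stated time of 96 h; on this read-out higher numbers stand for weaker inhibition of growth and lower numbers for stronger inhibition of growth.
Compound 2 `O=C(/C(=C\c1c(O)cc(O)cc1O)S(=O)(=O)c1ccccc1Br)c1ccc(Cl)cc1` gives 50000 nM in this assay.
Compound 3 `O=C(/C(=C\c1c(O)cc(O)cc1O)Sc1ccc(Br)cc1)c1ccc(Cl)cc1` gives 50000 nM in this assay.

Compound 2 stands level with compounds 1 and 3 at the digits shown; none of the three is separated from another beyond the scatter. The two steps among them are flat: no change at the digits printed from compound 1 to compound 2 (within the scatter), and no change at the digits printed from compound 2 to compound 3 (within the scatter). The second of these is the relevant one, since it already alters the group on the chain carbon that carries the sulfur, and the growth-inhibition read-out did not move.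

Compound 4 `Cc1ccc(CS(=O)(=O)/C(=C/c2c(O)cc(O)cc2O)C(=O)c2ccc(Cl)cc2)cc1` is the next member. The change from compound 2 is 4-methylbenzyl in place of 2-bromophenyl on a sulfonyl sulfur. For the measured compounds named here, the only measured step that bears on it is the change from compound 2 to compound 3, which exchanged the sulfur-bound aryl group and its oxidation state without effect. Going by the values given here, no step has moved the read-out at all, so the expected step in this assay is none beyond the scatter, no change at the digits printed from compound 2 to compound 4 (within the scatter). Compound 4 is therefore estimated at 50000 nM, with a range from 20000 nM to 100000 nM.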

Compound 4, concentration for 50% growth inhibition: > 100000 nM
Compound 4: only a limit was reported; the forecaster's own chance of this, stated with the estimate: 40%; middle value at least 2.0-fold (0.30 log units) away from the limit.
By their numbers in this assay, from the lowest: compounds 1, 2 and 3 (each within the scatter of the next). At a limit, above all of these: compound 4.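

Putting 4-methylbenzyl in place of 2-bromophenyl on the sulfonyl sulfur gives an at least 2.0-fold higher number from compound 2 to compound 4 (0.30 log units; that floor lies within the scatter), so the step has a floor but no upper bound, and that floor does not by itself separate the pair. In this assay compound 4 gives > 100000 nM, which is a limit of the assay and not a number. The earlier steps all sat level at one printed value, so this is the first change in the series after which the read-out is not at that value, though the size of the step cannot be told: the limit of > 100000 nM in this assay, at which 1 of the 4 values shown sits.

Open, from the compounds shown here alone, is whether the step goes with the benzyl link or with its methyl group, and plain benzyl on the sulfonyl sulfur would separate the two. Also open, going by these compounds, is how an amine or a carboxylic acid on that aromatic ring would read, and whether any change gives a lower number than compound 2 in this assay.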